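This account rests on a few compounds, and the source may have more. Where it says the series, first, only, none or still open, it means among the compounds named here.

Measured so far:
- compound 1 `Cc1cc(Nc2ccc(F)cc2)nc(Nc2ccc(NS(=O)(=O)c3ccccc3OC(F)(F)F)cc2)n1`; in a functional assay on MDA-MB-231 cells (Homo sapiens) for antiproliferative activity, read by MTT assay (a higher number here means a weaker inhibitor, a lower number a stronger inhibitor), compound 1 gives 23800 nM
- compound 2 `COc1ccc(Nc2cc(C)nc(Nc3ccc(NS(=O)(=O)c4c(Cl)cc(C)cc4OC)cc3)n2)cc1`; compound 2 reaches only a limit, > 50000 nM
- compound 3 `COc1ccc(Nc2ccnc(Nc3ccc(NS(=O)(=O)c4ccc(OC)cc4)cc3)n2)cc1`; compound 3 gives 6870 nM

Of the two numbers, compound 3 holds the lower one; compound 1 stands higher by a gap beyond the scatter, while compound 2 stops at the limit of > 50000 nM in this assay, at which 1 of the 3 values shown sits. Compound 4 `COc1ccc(Nc2ccnc(Nc3ccc(NS(=O)(=O)c4ccc(C)cc4)cc3)n2)cc1` differs from compound 3 only in methyl in place of methoxy on an aromatic carbon. For the measured compounds named here, no measured pair shows this change here, so its effect is unknown; a shift within the scatter, in either direction, is the expectation. Compound 4 is therefore estimated at 8000 nM, between 3000 nM and 25000 nM, which means an expected step of a 1.2-fold higher number from compound 3 to compound 4 (0.07 log units; within the scatter).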

Compound 4, half-maximal inhibitory concentration: 21200 nM
Estimate against measurement, compound 4: 2.7-fold (0.42 log units) below; the measured number falls inside the stated range.
By their numbers in this assay, from the lowest: compound 3; then compounds 4 and 1 (each within the scatter of the next). At a limit, above all of these: compound 2.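

Going from (4-methoxyphenyl)sulfonyl to (4-methylphenyl)sulfonyl in this assay gives a 3.1-fold higher number from compound 3 to compound 4 (0.49 log units; beyond the scatter) and this is the first comparison here of compounds that differ in one place. It shows that this position, on the ring para to a large group, responds to the change, with methoxy carrying the lower number of the pair. No measured property shown here bears on this step.

A single pair leaves open how far this holds on other cores. On these data alone, how a chlorine, an amine or a longer alkoxy chain would read at this position also remains open.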